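Methoxy Added to the Benzyl Arm of Compound 2

The source may hold more compounds than are shown below. What is called first, only, known or untested is meant among the compounds shown, and "the series" means these compounds.

Measured compounds:
compound 1 `CN(C)CC[C@H](CSc1ccccc1)Nc1ccc(S(=O)(=O)NC(=O)c2ccc(N3CCN(C(=O)Nc4ccccc4)CC3)cc2)cc1[N+](=O)[O-]`: 300 nM
compound 2 `CN(C)CC[C@H](CSc1ccccc1)Nc1ccc(S(=O)(=O)NC(=O)c2ccc(N3CCN(Cc4ccccc4)CC3)cc2)cc1[N+](=O)[O-]`: 39.8 nM

In an assay on isolated protein for displacement of a labelled ligand from Apoptosis regulator Bcl-2 (Homo sapiens), read by fluorescence polarization (a lower number here means a stronger inhibitor, a higher number a weaker inhibitor), compound 1 gives 300 nM and compound 2 gives 39.8 nM. Going by the values given here, the only measured step is a 7.5-fold lower number from compound 1 to compound 2 (0.88 log units; beyond the scatter), which exchanges the group on the ring amine nitrogen. Among the compounds with values here, on these numbers compound 2 stands lowest of the two, with compound 1 as its only neighbour and well beyond the scatter above it.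

Compound 3 `COc1ccccc1CN1CCN(c2ccc(C(=O)NS(=O)(=O)c3ccc(N[C@H](CCN(C)C)CSc4ccccc4)c([N+](=O)[O-])c3)cc2)CC1` keeps the benzyl arm of compound 2 and differs from it by methoxy in place of hydrogen on an aromatic carbon. No measured step bears on this part of the structure; the single step shown concerns the whole group on the ring nitrogen, not a substituent on its aromatic ring. With nothing to point either way, compound 3 is expected to stay close to compound 2, the step of a 1.1-fold lower number from compound 2 to compound 3 (0.06 log units; within the scatter) not going beyond the scatter. Compound 3 is therefore estimated at 35 nM in this assay, within 12 nM to 100 nM.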

Compound 3, inhibition constant: 3.2 nM
For compound 3 the middle estimate is 11-fold (1.04 log units) above the measured one; measured number outside the range, below it.
By their numbers in this assay, from the lowest: compound 3; then compound 2; then compound 1.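

In this assay, the aromatic ring of the benzyl arm proves sensitive to a small substituent: methoxy in place of hydrogen, ortho to a large group, gives a 12-fold lower number from compound 2 to compound 3 (1.09 log units; beyond the scatter). The earlier compounds had shown only that exchanging the whole group on the ring nitrogen matters, whereas the 2-methoxybenzyl group now stands against phenylcarbamoyl with a 94-fold lower number from compound 1 to compound 3 (1.97 log units; beyond the scatter), leaving compound 3 the strongest inhibitor of the three. No measurement shown here explains why this methoxy has so large an effect.

Whether the step belongs to methoxy itself remains open, since a hydroxy, an ethoxy or a chlorine on the same aromatic carbon is not among these compounds. Going by these compounds, it is equally open whether methoxy on another carbon of that ring, or a second methoxy, would give a similar number.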